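A few compounds are considered here, and "the series" means these few. Any claim that something is new, unique, unknown or untested is made for them only; others in the source may bear on it.

Of the compounds shown here, three built on one shared core have been tested in an assay on isolated protein for inhibition of malate dehydrogenase, mitochondrial (Sus scrofa), with stated times of 45 min and 30 min; a higher number here means a weaker inhibitor, a lower number a stronger inhibitor. Compound 1 `Cc1ccccc1S(=O)(=O)Nc1ccc(-c2nc3ccccc3o2)cc1` gives > 63000 nM in this assay, which is a limit of the assay rather than a number. Compound 2 `O=S(=O)(Nc1ccc(-c2nc3ccccc3o2)cc1)c1cccc(C(F)(F)F)c1` likewise gives > 63000 nM, again a limit. Compound 3 `O=S(=O)(Nc1ccc(-c2nc3ccccc3o2)cc1)c1cccc(O)c1` gives > 63000 nM, also a limit. So compound 3 stands at the edge of what this assay can report, and no number ranks it against the other two. The step from compound 1 to compound 3 is a step that the two limits leave unreadable from compound 1 to compound 3, and the step from compound 2 to compound 3 is a step that the two limits leave unreadable from compound 2 to compound 3: because all three values sit at the limit of > 63000 nM in this assay, at which 3 of the 3 values shown sit, neither step can be read in size or direction.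

Compound 4 `Cc1ccc(S(=O)(=O)Nc2ccc(-c3nc4ccccc4o3)cc2)cc1` has not yet been measured. It differs from compound 3 as follows: 4-methylphenyl in place of 3-hydroxyphenyl on a sulfonyl sulfur. Among the compounds with values here, the only comparable steps, the two just named, leave no readable size, so they give no basis for expecting a shift beyond the scatter; they show only that every group tried so far on the sulfonyl sulfur leaves the value at the limit. Compound 4 is therefore expected to sit at the limit as well, with an estimate of 100000 nM and a range from 40000 nM to 300000 nM. The step from compound 3 to compound 4 is accordingly estimated as a step that the limit leaves unreadable from compound 3 to compound 4, meaning no change that can be read.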

Compound 4, half-maximal inhibitory concentration: > 63000 nM
Compound 4 was reported as a limit (the forecaster's own chance of this, stated with the estimate: 85%); the middle value is on the limit's open side.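

Compound 4 gives > 63000 nM in this assay, which is a limit and not a number. The steps from compound 3 and from compound 1 to compound 4 cannot be read in size or direction, because all the values share one edge: the limit of > 63000 nM in this assay, at which 4 of the 4 values shown sit.

The compounds shown leave open whether any change to the shared core would give a measurable value in this assay.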